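Ester variation at the carbonyl of the shared core

The source may report more compounds than this note shows. Statements on the series, on what has been measured and on what is new or still open speak of the compounds shown alone.

Of the compounds shown here, two sharing a core have been measured in an assay on membranes from CHO cells for displacement of a labelled ligand from adenosine receptor A1 (Homo sapiens), read by scintillation counting, with a stated time of 60 min, tested at 1 uM; a higher number here means more inhibition at the concentration tested (going by the name of the read-out), a lower number less inhibition. Compound 1 `CCCC(=O)C1=C(C)NC(=O)NC1c1cccs1` gives 2%. Within the data shown here, compound 2 `CCN(CC)C(=O)C1=C(C)NC(=O)NC1c1cccs1` gives 13%, the higher of the two numbers, and the only step seen so far is a number 11 percentage points higher from compound 1 to compound 2 (beyond the scatter). Compound 3 `CCC(C)OC(=O)C1=C(C)NC(=O)NC1c1cccs1` is not yet measured. It differs from compound 2 in a single place: sec-butoxy in place of diethylamino on a carbonyl carbon. Among the measured compounds shown here, only the step from compound 1 to compound 2 bears on this change, and only loosely, since it concerned the same carbonyl carbon but a different pair of groups; it was modest in size. With one modest step and both measured numbers low, nothing in the data points to a rise, and compound 3 is expected to sit near or somewhat under compound 2, giving a number 5 percentage points lower from compound 2 to compound 3 (within the scatter). In this assay compound 3 is estimated at 8%, within 0% to 20%.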

Compound 3, a percentage reported as inhibition, at one concentration (the size of the read-out at that concentration, not a potency): 5%
Compound 3: the middle estimate sits 3 percentage points above what was measured, and the stated range covers the measured number.
By their numbers in this assay, from the lowest: compounds 1, 3 and 2 (each within the scatter of the next, the first and the last beyond it).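

In this assay sec-butoxy in place of diethylamino on the carbonyl carbon gives a number 8 percentage points lower from compound 2 to compound 3 (within the scatter) while sec-butoxy in place of propyl gives a number 3 percentage points higher from compound 1 to compound 3 (within the scatter) and thus compound 3 cannot be told apart from either, even though compound 1 and compound 2 stand beyond the scatter of each other. The diethylamino and sec-butoxy groups are therefore not separated at this position, and the earlier step from propyl to diethylamino does not by itself establish a preference for diethylamino over every other group here. No measurement at hand offers an explanation for these numbers.

From the compounds shown here alone, whether a cyclic amine such as piperidine would behave like diethylamino remains open. So does the outcome with a benzyloxy group or a free carboxylic acid on this carbonyl carbon.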